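Swapping a cyanophenyl for a thiophene: solubility outlook

The compounds below may be only part of what the source reports. "The series", "measured", "known", "first", "only" and "open" are said of these compounds alone.

Measured so far:
- compound 1 `Cc1cc(NCc2ncccn2)n2nc(C)c(-c3ccccc3)c2n1`: 37900 nM
- compound 2 `Cc1cc(NCc2ccccn2)n2ncc(-c3ccc(C#N)cc3)c2n1`: < 5000 nM

In a physicochemical assay for solubility, read by HPLC, using the shake flask method, measured as kinetic solubility, with a stated time of 2 h, at pH 7.4 (a lower number here means a less soluble compound, a higher number a more soluble compound), compound 1 gives 37900 nM. Compound 2 gives only < 5000 nM in this assay, which is a limit of the assay and not a number. Compound 2 therefore sits at the limit of < 5000 nM in this assay, at which 1 of the 2 values shown sits, and only a limit is known for it.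

The next compound, compound 3 `Cc1cc(NCc2ccccn2)n2ncc(-c3ccsc3)c2n1`, differs from compound 2 in one place: thiophen-3-yl in place of 4-cyanophenyl on an aromatic carbon. Within the data shown here, no step between two measured compounds with this same change is available, so the size of the effect rests on judgement alone. The step from compound 2 to compound 3 is expected to be an at least 1.4-fold higher number from compound 2 to compound 3 (0.14 log units; that floor lies within the scatter), a modest rise in solubility that may not exceed the usual scatter. Compound 3 is estimated at 7000 nM, with a range from 2500 nM to 20000 nM.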

Compound 3, solubility: 9000 nM
Compound 3: middle estimate off by 1.3-fold (0.11 log units), on the low side, and the stated range covers the measured number.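

Compound 3 gives a measured number at this position, 9000 nM in this assay. Compound 2 has only a limit of the assay and not a number: the limit of < 5000 nM in this assay, at which 1 of the 3 values shown sits. Thiophen-3-yl in place of 4-cyanophenyl on this aromatic carbon therefore gives an at least 1.8-fold higher number from compound 2 to compound 3 (0.25 log units; that floor lies within the scatter). Going by these compounds, this is only a floor because one end of the step is a limit, so the true size of the change remains unknown and could prove larger.

Compound 1 differs from compound 3 in more than one place, so its value cannot be tied to any single change. The compounds shown also leave open how a group carrying an amine or a carboxylic acid would behave on this aromatic carbon, with the rest of compound 3 unchanged.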